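The source may hold more compounds than are shown below. What is called first, only, known or untested is meant among the compounds shown, and "the series" means these compounds.

Compound 2 `CC(=O)Nc1ccc(S(=O)(=O)n2nc(-c3ccccc3)c3c(N)ncnc32)cc1` is tested in an ADME assay on MCF7 cells (Homo sapiens) for cytotoxicity, read by MTT assay, with a stated time of 48 h (on this read-out lower numbers stand for stronger inhibition and higher numbers for weaker inhibition), where compound 2 gives > 250000 nM, a figure that is a limit of the assay and not a number. Compound 1 `Nc1ncnc2c1c(-c1ccccc1)nn2S(=O)(=O)c1cc(Cl)ccc1Cl` has "not determined" (no result reported) in this assay. Compound 2 thus stands at the limit of > 250000 nM in this assay, at which 1 of the 2 values shown sits. Compound 3 `Cc1ccc(S(=O)(=O)n2nc(-c3ccccc3)c3c(N)ncnc32)cc1` carries methyl in place of acetamido on an aromatic carbon. Among the compounds with values here, no step between measured compounds is available, so in this assay the change is expected to bring no shift beyond the usual scatter, with an expected step of a number no higher from compound 2 to compound 3 (the limit leaves the size open). Compound 3 is therefore estimated at 250000 nM, within a range from 80000 nM to 600000 nM.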

Compound 3, half-maximal inhibitory concentration: > 250000 nM
Compound 3 gave a limit, no number; the forecaster's own chance of this, stated with the estimate: 70%; the middle value sits exactly at the limit.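

Compound 2 and compound 3 both give only a limit, not a number, and no step can be read between them in this assay: the limit of > 250000 nM in this assay, at which 2 of the 3 values shown sit.

The compounds shown leave open whether methyl and acetamido differ at all in this assay.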